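The compounds below may be only part of what the source reports. "The series", "measured", "known", "first", "only" and "open" are said of these compounds alone.

In a functional assay on SMMC-7721 cells (Homo sapiens) for inhibition, read by MTT assay, with a stated time of 48 h (a higher number here means a weaker inhibitor, a lower number a stronger inhibitor), three related compounds set the scene. Compound 1 `O=C(Nc1ccccn1)Nc1cc(-c2cncnc2)ccc1OC(F)(F)F` gives 21600 nM. For compound 2 `O=C(Nc1ccncc1)Nc1cc(-c2cccnc2)cc(C(F)(F)F)c1` the result reads "not determined" (no result reported). Compound 3 `COc1ccc(-c2cc(NC(=O)Nc3ccncc3)cc(C(F)(F)F)c2)cn1` stands at > 300000 nM, which is a limit of the assay and not a number. Compound 4 `O=C(Nc1ccncc1)Nc1cc(-c2cncnc2)cc(C(F)(F)F)c1` has pyrimidin-5-yl in place of 6-methoxypyridin-3-yl on an aromatic carbon, meta to a trifluoromethyl group (pyrimidin-5-yl in place of 6-methoxypyridin-3-yl on an aromatic carbon). No measured pair sizes this change directly. Compound 1 also carries pyrimidin-5-yl and gives 21600 nM, so a stronger reading is expected for compound 4. The expected shift towards stronger inhibition in this assay is an at least 5.0-fold lower number from compound 3 to compound 4 (0.69 log units; beyond the scatter). For compound 4 the estimated value is 60000 nM, within an expected range of 15000 nM to 250000 nM.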

Compound 4, half-maximal inhibitory concentration: 3730 nM
The estimate for compound 4 lay 16-fold (1.21 log units) above the measured number; the whole stated range lies above it.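

In this assay, the aromatic carbon meta to a trifluoromethyl group proves highly sensitive to the group it carries: pyrimidin-5-yl in place of 6-methoxypyridin-3-yl gives an at least 80-fold lower number from compound 3 to compound 4 (1.90 log units; beyond the scatter). Among the compounds shown here, this is the first readable step at this position, and it is large. Its true size stays open, as compound 3 stands at a limit of the assay and not at a number: the limit of > 300000 nM in this assay, at which 1 of the 4 values shown sits.

The compounds shown do not separate the loss of the methoxy group from the change to pyrimidin-5-yl. On these data alone, how an amine or a carboxylic acid on this ring would read also remains open.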